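The compounds below may be only part of what the source reports. "The series", "measured", "known", "first", "only" and "open" are said of these compounds alone.

Measured compounds in the series:
compound 1 `CC(=O)N1CCC(c2ccc3c(c2)oc(=O)n3C(=O)NCCCCc2ccccc2)CC1`: 64 nM
compound 2 `CCN1CCN(c2ccc3c(c2)oc(=O)n3C(=O)NCCCCc2ccccc2)CC1`: 56 nM
compound 3 `CC(C)CN1CCN(c2ccc3c(c2)oc(=O)n3C(=O)NCCCCc2ccccc2)CC1`: 127 nM

All three numbers come from an assay on HEK293 cells for inhibition of acid ceramidase (Homo sapiens), read by fluorescence, with stated times of 10 min and 3 h; on this read-out higher numbers stand for weaker inhibition and lower numbers for stronger inhibition. Compound 3 gives the highest number of the three; against compound 1 the gap is a 2.0-fold higher number from compound 1 to compound 3 (0.30 log units; within the scatter), against compound 2 it is a 2.3-fold higher number from compound 2 to compound 3 (0.36 log units; beyond the scatter). Compounds 1 and 2 sit within the scatter of each other, shown by a 1.1-fold lower number from compound 1 to compound 2 (0.06 log units; within the scatter).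

Compound 4 `CCN1CCC(c2ccc3c(c2)oc(=O)n3C(=O)NCCCCc2ccccc2)CC1` is not yet measured. It differs from compound 3 in one place: 1-ethylpiperidin-4-yl in place of 4-isobutylpiperazin-1-yl on an aromatic carbon. For the measured compounds named here, two measured steps bear on this. The change from compound 3 back to a ring carrying a smaller substituent, as in compound 2, was a modest lowering of the number; the change to the carbon-linked piperidine ring, as in compound 1, left the number within the scatter. Compound 4 combines the ethyl on the ring nitrogen of compound 2 with the carbon-linked piperidine ring of compound 1, so a modest lowering of the number relative to compound 3 is expected in this assay, back to the level of compounds 1 and 2.

For compound 4 the estimate is 65 nM, with a range from 30 nM to 140 nM, which means an expected step of a 2.0-fold lower number from compound 3 to compound 4 (0.29 log units; within the scatter).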

Compound 4, half-maximal inhibitory concentration: 92 nM
Beside the measured number, compound 4's estimate is 1.4-fold (0.15 log units) below it; low and high end bracket the measured number.
By their numbers in this assay, from the lowest: compounds 2, 1, 4 and 3 (each within the scatter of the next, the first and the last beyond it).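

In this assay, the change of ring alone, with the ethyl kept, gives a 1.6-fold higher number from compound 2 to compound 4 (0.22 log units; within the scatter), so 1-ethylpiperidin-4-yl and 4-ethylpiperazin-1-yl on this aromatic carbon are not told apart; the earlier comparison of compound 1 with compound 2 changed the ring and the nitrogen substituent together. With the piperidine ring held constant, ethyl in place of acetyl on the ring nitrogen gives a 1.4-fold higher number from compound 1 to compound 4 (0.16 log units; within the scatter), so here the alkyl and acyl groups are not told apart either. The remaining comparison, a 1.4-fold lower number from compound 3 to compound 4 (0.14 log units; within the scatter), also stays within the scatter, leaving the step from compound 2 to compound 3 as the only one in the series beyond it.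

As far as these compounds go, whether a piperidine nitrogen bearing only hydrogen, a longer chain or a carboxylic acid at this position would stay in the same range remains open. No supporting data explain these steps.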